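Swapping the Amide Cap: tert-Butyl to Difluorophenyl

The compounds below may be only part of what the source reports. "The series", "measured", "known", "first", "only" and "open" are said of these compounds alone.

Among the compounds with values here, compound 2 `CC(C)(C)C(=O)N1CCC(NCCSC(c2ccc(F)cc2)c2ccc(F)cc2)CC1` gives 163 nM in an assay on membranes from Cortex for displacement of a labelled ligand from Sigma non-opioid intracellular receptor 1 (Cavia porcellus), read by scintillation counting, with a stated time of 120 min (a higher number here means a weaker inhibitor, a lower number a stronger inhibitor), the lowest of the two numbers measured so far, though its only neighbour, compound 1 `O=C(c1cc2ccccc2o1)N1CCC(NCCSC(c2ccc(F)cc2)c2ccc(F)cc2)CC1`, gives 304 nM and sits within the scatter of it. Within the data shown here, the single measured step, a 1.9-fold lower number from compound 1 to compound 2 (0.27 log units; within the scatter), exchanged one group on the carbonyl carbon for another and left the number essentially where it was. Compound 3 `O=C(c1ccc(F)cc1F)N1CCC(NCCSC(c2ccc(F)cc2)c2ccc(F)cc2)CC1` carries a change at the same place: 2,4-difluorophenyl in place of tert-butyl on a carbonyl carbon. Among the measured compounds shown here, that earlier step is the only guide, and it bears directly on this one because a 1.9-fold lower number from compound 1 to compound 2 (0.27 log units; within the scatter) also swapped a ring-bearing group against tert-butyl on that carbonyl carbon. Compound 3 is therefore expected to land near 220 nM in this assay, with a range from 80 nM to 600 nM. The expected step of a 1.3-fold higher number from compound 2 to compound 3 (0.13 log units; within the scatter) should stay within the scatter.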

Compound 3, inhibition constant: 20.6 nM
Estimate against measurement, compound 3: 11-fold (1.03 log units) above, outside the stated range (below it).
By their numbers in this assay, from the lowest: compound 3; then compounds 2 and 1 (each within the scatter of the next).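

In this assay, the group on this carbonyl carbon clearly matters: the change gives a 7.9-fold lower number from compound 2 to compound 3 (0.90 log units; beyond the scatter) and, measured against the other cap, a 15-fold lower number from compound 1 to compound 3 (1.17 log units; beyond the scatter). The earlier swap between tert-butyl and 1-benzofuran-2-yl stayed within the scatter, so carrying a ring at this place does not by itself go with a lower number, and 2,4-difluorophenyl stands apart from both, with compound 3 the strongest of the three. Nothing measured here explains this difference.

The compounds shown leave open whether the two fluorines are needed, which a plain phenyl on the same carbonyl would test, or whether another ring, such as a pyridine, would serve as well. They also leave open whether 2,4-difluorophenyl gives a similar step on a different core.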